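The compounds below may be only part of what the source reports. "The series", "measured", "known", "first", "only" and "open" are said of these compounds alone.

Measured in a functional assay on A549 cells (Homo sapiens) for cytotoxicity, read by sulforhodamine B assay, with a stated time of 48 h; on this read-out lower numbers stand for stronger inhibition and higher numbers for weaker inhibition:
Compound 1 `COc1cc(/C=C/C(=O)c2ccc(N)c(-c3ccc(F)cc3)c2)cc(Br)c1O`: > 50000 nM (a limit of the assay)
Compound 2 `COc1cc(/C=C/C(=O)c2ccc(N)c(-c3ccc(F)cc3)c2)ccc1O`: 12200 nM
Compound 3 `COc1ccc(/C=C/C(=O)c2ccc(N)c(-c3ccc(F)cc3)c2)cc1OC`: 8630 nM

Compound 2 gives 12200 nM, and compound 3 gives 8630 nM, so these two numbers lie within the scatter of each other. Compound 1 reports only a limit, > 50000 nM.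

The unmeasured compound 4 `Nc1ccc(C(=O)/C=C/c2ccc(O)c(F)c2)cc1-c1ccc(F)cc1` keeps the rest of compound 2 and changes 4-hydroxy-3-methoxyphenyl to 3-fluoro-4-hydroxyphenyl, with fluoro in place of methoxy on an aromatic carbon, ortho to a hydroxy group (fluoro in place of methoxy on an aromatic carbon).

Among the compounds with values here, two measured steps touch the same ring. Losing the bromo gives an at least 4.0-fold lower number from compound 1 to compound 2 (0.61 log units; beyond the scatter), a step beyond the scatter that rests on a limit. Adding the methyl on the oxygen gives a 1.4-fold lower number from compound 2 to compound 3 (0.15 log units; within the scatter), a step within the scatter. Neither step exchanges methoxy for fluoro, so both are only loose guides. The methyl step shows that altering the methoxy's neighbourhood need not move the number, while the bromo step shows that a change on this ring can. No clear direction follows from them, and a change no larger than the scatter is expected. The estimated step is a 1.1-fold higher number from compound 2 to compound 4 (0.03 log units; within the scatter). For compound 4 the expected value is 13000 nM, with an estimated range of 5500 nM to 32000 nM.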

Compound 4, half-maximal inhibitory concentration: 24500 nM
Estimate against measurement, compound 4: 1.9-fold (0.28 log units) below, within the range that was stated.
By their numbers in this assay, from the lowest: compounds 3, 2 and 4 (each within the scatter of the next, the first and the last beyond it). At a limit, above all of these: compound 1.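

In this assay, replacing methoxy with fluoro on an aromatic carbon, ortho to a hydroxy group, gives a 2.0-fold higher number from compound 2 to compound 4 (0.30 log units; within the scatter). Within the data shown here, the earlier steps removed a bromo from the same ring or added a methyl on an oxygen, so this is the first reading in which the methoxy group itself leaves, and the step shows that this exchange can be made without a change this read-out separates from repeated measurement. Compound 1 alone sits at a limit of the assay, while compound 4 gives a number that can be compared directly with that of compound 2: the limit of > 50000 nM in this assay, at which 1 of the 4 values shown sits.

The compounds shown leave open whether other groups at this position, such as chloro, ethoxy, a nitrile or an amine, would also stay within the scatter of compound 2. They also leave open whether fluoro in place of methoxy would read the same with a methyl on the oxygen of the 4-hydroxy group, or with the bromo of compound 1 kept on the ring.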